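A few compounds are considered here, and "the series" means these few. Any claim that something is new, unique, unknown or untested is made for them only; others in the source may bear on it.

Three compounds have so far been measured in an ADME assay on HepG2 cells (Homo sapiens) for cytotoxicity, with a stated time of 72 h; a lower number here means that less compound is needed, a higher number that more compound is needed for the effect:

compound 1, `O=C(Nc1ccc(F)c(-c2nc3ccccc3s2)c1)c1cc([N+](=O)[O-])ccc1Cl`, gives only a limit, > 25000 nM.
compound 2, `O=C(Nc1cccc(-c2nc3ccccc3s2)c1)c1cc([N+](=O)[O-])ccc1Cl`, gives only a limit, > 27000 nM.
compound 3, `O=C(Nc1nc(-c2cccc(F)c2)cs1)c1cc([N+](=O)[O-])ccc1Cl`, gives 18000 nM.

Compound 3 is the only one of the three with a number rather than a limit in this assay.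

Compound 4, `O=C(Nc1nc(-c2ccc(F)c(F)c2)cs1)c1cc([N+](=O)[O-])ccc1Cl`, has not yet been measured in this assay. It differs from compound 3 in one place: fluoro in place of hydrogen on an aromatic carbon. The core of compound 3 and the core of compound 2 are not the same, and the difference between the two cores is not broken down here.

The same kind of change is found between two of the measured compounds: fluoro in place of hydrogen on an aromatic carbon. The surroundings of the place are not the same word for word: in compound 4 the entering fluoro sits ortho to a fluoro group, whereas in compound 1 it sits ortho to a 1,3-benzothiazol-2-yl group. The step that the two limits leave unreadable from compound 2 to compound 1 cannot be read, because the limit of > 25000 nM in this assay, at which 1 of the 3 values shown sits, and (the limit of > 27000 nM in this assay, at which 1 of the 3 values shown sits). Going by the values given here, the earlier pair therefore gives no size for the step.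

With no readable size from the earlier pair, the step of no change at the digits printed from compound 3 to compound 4 (within the scatter) is expected to stay within the usual scatter of this kind of measurement. Compound 4 is expected to give about 18000 nM, with a range from 9000 nM to 36000 nM.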

Compound 4, half-maximal effective concentration: > 27000 nM
Compound 4: a limit, no number; the forecaster's own chance of this, stated with the estimate: 30%; middle value at least 1.5-fold (0.17 log units) from the limit.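

In this assay, compound 4 gives > 27000 nM, which is a limit and not a number. On this core, fluoro in place of hydrogen, which turns 3-fluorophenyl into 3,4-difluorophenyl, gives an at least 1.5-fold higher number from compound 3 to compound 4 (0.17 log units; that floor lies within the scatter), and the full size of the step stays open because compound 4 stands at a limit: the limit of > 27000 nM in this assay, at which 2 of the 4 values shown sit.

The same change on the core of compound 2 offers no size to set beside this one, so the data show neither that the change carries over from one core to the other nor that it does not, because the step to compound 1 also ends in a limit and cannot be read: the limit of > 25000 nM in this assay, at which 1 of the 4 values shown sits.

Among the compounds shown, fluoro is the only group that enters in place of hydrogen on these aromatic carbons, so it remains open what a group of another kind, such as an amine or a carboxylic acid, would do at the same place on either core. On these data alone, it also remains open how far past its limit compound 4 lies, and whether any change on the core of compound 2 would give a number that could be compared across the two cores.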